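Chain length between the shared core and the terminal group

The source may hold more compounds than are shown below. What is called first, only, known or untested is meant among the compounds shown, and "the series" means these compounds.

Compound 1 `C/N=C(\S)CCn1nc(-c2ccccc2)ccc1=O` gives 58.5 mg/kg in a functional assay on the whole organism (stomach) with Rattus norvegicus as the target; on this read-out lower numbers stand for an effect already at smaller amounts and higher numbers for an effect only at larger amounts of compound.
Compound 3 `C/N=C(/S)CCCCCn1nc(-c2ccccc2)ccc1=O` gives 25.2 mg/kg in this assay.
Compound 2 `Cc1ccc(=O)n(CCCCC(=N)S)n1` gives only a limit in this assay, > 100 mg/kg.

Compound 3 stands lowest of the two numbers shown; compound 1 is the nearest, and the step of a 2.3-fold lower number from compound 1 to compound 3 (0.37 log units; beyond the scatter) shows that the longer chain brings the lower number. Compound 4 `N=C(S)CCCCn1nc(-c2ccccc2)ccc1=O` differs from compound 3 by a group of 3 heavy atoms (1 carbon, 1 nitrogen, 1 sulfur; no ring) in place of a group of 5 heavy atoms (3 carbon, 1 nitrogen, 1 sulfur; no ring), on a saturated chain carbon, four bonds along the chain from an aromatic nitrogen. For the measured compounds named here, this shortens the chain again, partly reversing the lengthening of that measured step, and also alters the terminal group, for which no measured step exists. Compound 2 gives no number, only a limit. Compound 4 is therefore expected to show a higher number in this assay, the step being a 2.0-fold higher number from compound 3 to compound 4 (0.30 log units; within the scatter). For compound 4 the estimate is 50 mg/kg, expected between 22 mg/kg and 120 mg/kg.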

Compound 4, dose for half-maximal effect: > 100 mg/kg
Compound 4 ended at the assay's limit (the forecaster's own chance of this, stated with the estimate: 15%); at least 2.0-fold (0.30 log units) between middle value and limit.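

In this assay, the change at this position gives an at least 3.9-fold higher number from compound 3 to compound 4 (0.59 log units; beyond the scatter), so removing the methyl on the terminal nitrogen while shortening the chain costs more than the earlier chain step suggested. Compared with compound 1, the result is an at least 1.7-fold higher number from compound 1 to compound 4 (0.23 log units; that floor lies within the scatter), so the longer chain of compound 4 brings no lower number, and chain length alone does not order these compounds. The step between compound 2 and compound 4 cannot be read, as both values are limits: the limit of > 100 mg/kg in this assay, at which 2 of the 4 values shown sit.

Chain and terminal group change together in both readable steps, so their separate shares remain unresolved. From the compounds shown here alone, the effect of a longer chain, or of an ethyl on the terminal nitrogen, also remains open.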